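Trifluoromethyl for Chloro on the Benzyl Arm

The compounds below may be only part of what the source reports. "The series", "measured", "known", "first", "only" and "open" are said of these compounds alone.

Three measured compounds share one core. Compound 1 `Cc1c(Cc2ccccc2)c(=O)oc2cc(OCC(O)CNn3ccnn3)ccc12` reaches only the limit of > 100000 nM in an ADME assay on A549 cells (Homo sapiens) for cytotoxicity, read by CellTiter-Glo; a lower number here means that less compound is tolerated, a higher number that more compound is tolerated. Compound 2 `Cc1ccc2nc(NCC(O)COc3ccc4c(C)c(Cc5ccccc5)c(=O)oc4c3)sc2c1` likewise reaches only the limit of > 100000 nM in this assay. The step that the two limits leave unreadable from compound 1 to compound 2 is therefore unreadable, as the limit of > 100000 nM in this assay, at which 2 of the 3 values shown sit, makes clear. Within the data shown here, compound 3 `Cc1c(Cc2ccc(Cl)cc2)c(=O)oc2cc(OCC(O)CN3CCC(C(N)=O)CC3)ccc12` gives 40000 nM in this assay, the only number among the three values. Among the measured compounds shown here, compound 4 `Cc1c(Cc2ccc(C(F)(F)F)cc2)c(=O)oc2cc(OCC(O)CN3CCC(C(N)=O)CC3)ccc12` differs from compound 3 by trifluoromethyl in place of chloro on an aromatic carbon, a change on the benzyl arm rather than on the amine nitrogen where the one measured step sits. For the measured compounds named here, no measured step bears on this change, so no step beyond the scatter is expected in this assay. Compound 4 is thus expected to give 40000 nM, between 15000 nM and 100000 nM. The expected step is no change at the digits printed from compound 3 to compound 4 (within the scatter).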

Compound 4, half-maximal cytotoxic concentration: 89300 nM
Compound 4: the middle estimate sits 2.2-fold (0.35 log units) below what was measured; the range from low to high includes it.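

In this assay, the benzyl arm proves to be a place where a change can be read: trifluoromethyl in place of chloro gives a 2.2-fold higher number from compound 3 to compound 4 (0.35 log units; beyond the scatter). Among these compounds, the earlier compounds offered no such reading, since their only step cannot be read, so this is the first step with a size. Any further rise would soon be lost at the top of the readable range: the limit of > 100000 nM in this assay, at which 2 of the 4 values shown sit.

As far as these compounds go, whether a nitrile or a methoxy group on the same aromatic carbon would also shift the number stays open. So does whether this change would hold with an amine other than the piperidine carboxamide of compound 3 and compound 4.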